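Cytotoxicity notes on a fused bicyclic chloro series

The source may report more compounds than this note shows. Statements on the series, on what has been measured and on what is new or still open speak of the compounds shown alone.

Measured so far:
- compound 1, `CSc1nc(Cl)c2ccn(COCCO)c2n1`; in a functional assay on HFF cells (Homo sapiens) for cytotoxicity (a higher number here means a weaker inhibitor, a lower number a stronger inhibitor), compound 1 gives 30000 nM.
- compound 2, `CC(=O)OCCOCn1ccc2c(Cl)nc(Cl)nc21`; in this assay compound 2 gives > 100000 nM, a limit of the assay and not a number.
- compound 3, `OCCOCn1ccc2c(Cl)nc(Cl)nc21`; in this assay compound 3 gives 100000 nM.

Compound 3 stands at the highest of the two numbers read; its nearest neighbour is compound 1, with a 3.3-fold higher number from compound 1 to compound 3 (0.52 log units; beyond the scatter). Compound 2 sits at the limit of > 100000 nM in this assay, at which 1 of the 3 values shown sits, so a number no higher from compound 2 to compound 3 (the limit leaves the size open), and the size of that step is not readable.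

The next compound is compound 4, `CC(=O)Nc1nc(Cl)c2ccn(COCCO)c2n1`. The change from compound 3 is acetamido in place of chloro on an aromatic carbon. Going by the values given here, the only step at the same aromatic carbon is the one from compound 1 to compound 3, which was modest; the step from compound 2 to compound 3 concerns the other end of the molecule and gives no size. Among the compounds with values here, no measured step covers an acetamido group, so the expectation for compound 4 in this assay rests on the modest size of the one comparable step and allows a change in either direction or none beyond the scatter.

The expected step is estimated as no change at the digits printed from compound 3 to compound 4 (within the scatter). For compound 4 in this assay the estimated value is 100000 nM, with a range from 30000 nM to 300000 nM.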

Compound 4, half-maximal inhibitory concentration: > 100000 nM
Compound 4: only a limit was reported; the forecaster's own chance of this, stated with the estimate: 40%; the middle value sits exactly at the limit.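

At the aromatic carbon between two ring nitrogen atoms, acetamido in place of methylsulfanyl gives an at least 3.3-fold higher number from compound 1 to compound 4 (0.52 log units; beyond the scatter) in this assay, so methylsulfanyl now has the lower number against two different groups at this position, chloro and acetamido. Compound 4 gives a limit of the assay and not a number: the limit of > 100000 nM in this assay, at which 2 of the 4 values shown sit. Acetamido in place of chloro gives a number no lower from compound 3 to compound 4 (the limit leaves the size open) in this assay. The size of this step cannot be read, and neither can that of the step from compound 2 to compound 3, so acetamido and chloro cannot be ranked against each other at this position.

The compounds shown leave open whether a free amine at this position would give a number nearer that of compound 1 or stay at the limit. They also leave open whether a longer sulfur-linked chain, such as ethylsulfanyl, would give a lower number than methylsulfanyl.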